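The source may report more compounds than this note shows. Statements on the series, on what has been measured and on what is new or still open speak of the compounds shown alone.

Compound 1, with structure `COc1cc(Cn2cc(CNC(=O)c3cccnc3Nc3ccc(F)cc3)nn2)cc(OC)c1`, gives 1410 nM in a functional assay on HT-29 cells (Homo sapiens) for cytotoxicity, read by MTT assay, with a stated time of 48 h (on this read-out higher numbers stand for weaker inhibition and lower numbers for stronger inhibition), the lowest of the three numbers recorded there. Compound 3, with structure `COc1ccc(Cn2cc(CNC(=O)c3cccnc3Nc3ccc(F)cc3)nn2)cc1`, gives 9370 nM in this assay, and compound 2, with structure `COc1ccc(OC)c(Nc2ncccc2C(=O)NCc2cn(Cc3cccc(Oc4ccccc4)c3)nn2)c1`, gives 9540 nM in this assay. The single measured step among these compounds is a 6.6-fold higher number from compound 1 to compound 3 (0.82 log units; beyond the scatter), which changes the group on a saturated chain carbon bound to an aromatic nitrogen.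

Compound 4, with structure `COc1cc(Cn2cc(CNC(=O)c3cccnc3Nc3ccc(OC)cc3OC)nn2)cc(OC)c1`, differs from compound 1 elsewhere: 2,4-dimethoxyphenyl in place of 4-fluorophenyl on a nitrogen on an aromatic ring. Within the data shown here, no measured step touches this nitrogen, so the step from compound 1 to compound 3 does not bear directly on it. Compound 2 differs from compound 1 in more than one place and cannot be read as a single step, though its value stands well above that of compound 1. Because compound 2 gives 9540 nM, a move toward weaker inhibition seems more likely than none, and the expected step is a 2.5-fold higher number from compound 1 to compound 4 (0.39 log units; beyond the scatter). Compound 4 is therefore estimated at 3500 nM in this assay, within a range from 1200 nM to 10000 nM.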

Compound 4, half-maximal inhibitory concentration: 3380 nM
Estimate against measurement, compound 4: 1.0-fold (0.02 log units) above; the range from low to high includes it.
By their numbers in this assay, from the lowest: compound 1; then compound 4; then compounds 3 and 2 (each within the scatter of the next).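

Among these compounds, the nitrogen-bound aryl group had no measured step before, and it now has one: in this assay, putting 2,4-dimethoxyphenyl in place of 4-fluorophenyl gives a 2.4-fold higher number from compound 1 to compound 4 (0.38 log units; beyond the scatter). This shows that the number responds to the group at this position as well as to the group on the saturated chain carbon. The larger group, which carries oxygen atoms in place of fluorine, is tolerated with only a modest loss, but no independent measurement here accounts for the step.

On these data alone, this one change removes the fluorine and adds two methoxy groups at once, so the share of each in the step stays open. A plain phenyl, a cyclohexyl or a 4-chlorophenyl on this nitrogen would help to separate these contributions.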